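A few compounds are considered here, and "the series" means these few. Any claim that something is new, unique, unknown or untested is made for them only; others in the source may bear on it.

Measured in a physicochemical assay for solubility, at pH 6.5; on this read-out lower numbers stand for lower solubility and higher numbers for higher solubility:
Compound 1, `CS(=O)(=O)c1ccc(-c2cnc3ccc(-c4cncc(S(C)(=O)=O)c4)nn23)cc1`, gives < 5000 nM, which is a limit.
Compound 2, `CS(=O)(=O)c1ccc(-c2cnc3ccc(-c4cccc(C(=O)NCCO)c4)nn23)cc1`, gives > 100000 nM, which is a limit.
Compound 3, `CS(=O)(=O)c1ccc(-c2cnc3ccc(-c4cccc(S(=O)(=O)C5CC5)c4)nn23)cn1`, gives < 5000 nM, which is a limit.

Compound 2 stands at the upper end of the three readings: its result is the limit of > 100000 nM in this assay, at which 1 of the 3 values shown sits, so only a limit and no number is known for it. Compound 1 and compound 3 both sit at the limit of < 5000 nM in this assay, at which 2 of the 3 values shown sit, again limits rather than numbers. Within the data shown here, with every value a limit, no measured step between these compounds can be sized; all that can be said is that compound 2 sits at one end of this assay and the other two compounds at the other.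

Compound 4, `C[S+]([O-])c1cccc(-c2ccc3ncc(-c4ccc(S(C)(=O)=O)cc4)n3n2)c1`, has not yet been measured in this assay. It differs from compound 2 in one place: a group of 3 heavy atoms (1 carbon, 1 oxygen, 1 sulfur; no ring) in place of a group of 6 heavy atoms (3 carbon, 1 nitrogen, 2 oxygen; no ring), on an aromatic carbon. Since compound 2 is known only as a limit, the expectation cannot rest on a measured pair; it rests on compound 1 and compound 3, which both sit at the limit of < 5000 nM in this assay, at which 2 of the 3 values shown sit. A downward step, beyond the usual scatter, is expected: an at least 4.0-fold lower number from compound 2 to compound 4 (0.60 log units; beyond the scatter). Compound 4 is estimated at 25000 nM, with a range from 4000 nM to 100000 nM.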

Compound 4, solubility: 157000 nM
For compound 4 the middle estimate is 6.3-fold (0.80 log units) below the measured one; measured number above the stated range.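

In this assay compound 2 gives > 100000 nM, which is a limit and not a number, so the step from compound 2 to compound 4 cannot be read. The compounds shown leave open how large that step is, and whether compound 4 stands higher or lower than compound 2 or within the usual scatter of it.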